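A few compounds are considered here, and "the series" means these few. Any claim that something is new, unique, unknown or untested is made for them only; others in the source may bear on it.

Two compounds of the series have numbers in an ADME assay on microsomes from liver (Mus musculus) for metabolic stability, with a stated time of 30 min (on this read-out lower numbers stand for a less stable compound and higher numbers for a more stable compound), so far. Compound 1 `CC#CCOC(=O)Cc1c(C(C)C)nc(CCCC)n(Cc2ccc(-c3ccccc3-c3noc(=O)[nH]3)cc2)c1=O` gives 16.4% in this assay. Compound 2 `CCCCc1nc(C)c(CC(=O)OCC2CC2)c(=O)n1Cc1ccc(-c2ccccc2-c2noc(=O)[nH]2)cc1` gives 13% in this assay, the lowest of the two numbers, with compound 1 nearest and within the scatter of it, so no order between the two can be read. Compound 3 `CC#CCOC(=O)Cc1c(C)nc(CCCC)n(Cc2ccc(-c3ccccc3-c3noc(=O)[nH]3)cc2)c1=O` has not been measured; it differs from compound 2 in one place: prop-1-yn-1-yl in place of cyclopropyl on a saturated chain carbon bound to an oxygen next to a carbonyl group. Among the measured compounds shown here, the group that enters is the one compound 1 carries at that place, while the rest of compound 3 stays as in compound 2. For the measured compounds named here, no measured pair isolates this change, so no step for it is known; the two values in hand, compound 1 at 16.4% and compound 2 at 13%, lie within the scatter of each other, and no step beyond the scatter is expected in this assay. The step expected for this change is a number 2 percentage points higher from compound 2 to compound 3 (within the scatter). Compound 3 is estimated at 15% in this assay, with a range from 6% to 28%.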

Compound 3, percent of the compound remaining: 18.3%
Compound 3: middle estimate off by 3.3 percentage points, on the low side; the measured number falls inside the stated range.
By their numbers in this assay, from the lowest: compounds 2, 1 and 3 (each within the scatter of the next).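

In this assay, the change at the first place now has a measured pair: prop-1-yn-1-yl in place of cyclopropyl on a saturated chain carbon bound to an oxygen next to a carbonyl group gives a number 5.3 percentage points higher from compound 2 to compound 3 (within the scatter). A second place also gains its first pair, as methyl in place of isopropyl on an aromatic carbon gives a number 1.9 percentage points higher from compound 1 to compound 3 (within the scatter), so neither change shows a step beyond the scatter on this read-out. No measured information bears on these results.

On these data alone, whether any group at either place can give a step beyond the scatter stays open. A phenyl or a dimethylamino group on the saturated chain carbon, or a trifluoromethyl on the aromatic carbon, would test this.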